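A Cytotoxicity Limit Carried From Compound 1 to Compound 3

The source may report more compounds than this note shows. Statements on the series, on what has been measured and on what is new or still open speak of the compounds shown alone.

Compound 1 `Cc1cncc(-c2ccc3[nH]c(=O)nc(-c4ccccc4)c3c2)c1` was tested in an ADME assay on THP-1 cells (Homo sapiens) for cytotoxicity, read by MTT assay, with a stated time of 72 h; on this read-out lower numbers stand for an effect already at smaller amounts and higher numbers for an effect only at larger amounts of compound. In this assay compound 1 returns > 50000 nM, which is a limit of the assay and not a measured number. For the measured compounds named here, compound 2 `CN(C)c1ccc(-c2ccc3[nH]c(=O)nc(-c4ccccc4)c3c2)cn1` shares the core of compound 1 and is the only other compound measured. In this assay compound 2 gives > 50000 nM, again a limit rather than a number. Compound 1 therefore stands at the limit of > 50000 nM in this assay, at which 2 of the 2 values shown sit, and nothing measured sets it apart from compound 2.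

Compound 3 `N#Cc1ccc(-c2ccc3[nH]c(=O)nc(-c4ccccc4)c3c2)cc1` has not yet been measured in this assay. It differs from compound 1 in one place: 4-cyanophenyl in place of 5-methylpyridin-3-yl on an aromatic carbon. Going by the values given here, no step between two measured compounds covers this change, so there is no measured precedent for it. With both shown values sitting at the same boundary, the step from compound 1 to compound 3 is expected to be a number no higher from compound 1 to compound 3 (the limit leaves the size open), that is, none beyond the scatter in either direction. In this assay compound 3 is estimated at 50000 nM, with a range from 20000 nM to 100000 nM, and it is expected most often to be reported again only as a limit.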

Compound 3, half-maximal effective concentration: > 50000 nM
Compound 3: no number, only a limit; the forecaster's own chance of this, stated with the estimate: 75%; the middle value sits exactly at the limit.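

In this assay no step can be read between compound 1 and compound 3, as the values of both are limits of the assay and not numbers: the limit of > 50000 nM in this assay, at which 3 of the 3 values shown sit. The compounds shown leave open at what concentration any of them would affect these cells, and whether 4-cyanophenyl in place of 5-methylpyridin-3-yl shifts that concentration at all.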